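From Compound 3 to Its Chloro Analogue

This account rests on a few compounds, and the source may have more. Where it says the series, first, only, none or still open, it means among the compounds named here.

In an ADME assay on NIH3T3 cells (Mus musculus) for cytotoxicity, read by MTT assay, with a stated time of 48 h (a higher number here means that more compound is tolerated, a lower number that less compound is tolerated), compound 1 (`COc1ccc(C(C)=O)cc1S(=O)(=O)Nc1c(N)nc(SC)[nH]c1=O`) stands at > 1600000 nM which is a limit of the assay. Compound 3 (`COc1ccc(C(=O)/C=C/c2ccccc2)cc1S(=O)(=O)Nc1c(N)nc(SC)[nH]c1=O`) gives 17000 nM as the higher of the two actual numbers, and compound 2 (`COc1ccc(C(=O)/C=C/c2ccc(Cl)cc2)cc1S(N)(=O)=O`) gives 4100 nM which lies lower, beyond the scatter. Compound 4 (`COc1ccc(C(=O)/C=C/c2ccc(Cl)cc2)cc1S(=O)(=O)Nc1c(N)nc(SC)[nH]c1=O`) differs from compound 3 by chloro in place of hydrogen on an aromatic carbon. Among the compounds with values here, the only measured step at that end of the molecule, 2-phenylethenyl in place of methyl on a carbonyl carbon, was large (an at least 94-fold lower number from compound 1 to compound 3 (1.97 log units; beyond the scatter)), but it exchanged far more than a single chloro does. Compound 2 already carries 2-(4-chlorophenyl)ethenyl and sits at 4100 nM but differs from compound 4 elsewhere as well, so it offers only a weak hint of a lower number. A small fall, within the scatter, is therefore expected, and the estimated step is a 1.9-fold lower number from compound 3 to compound 4 (0.28 log units; within the scatter) in this reading. In this assay the expected value for compound 4 is 9000 nM with 3500 nM to 23000 nM as its estimated range.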

Compound 4, concentration lethal to 50% of the cells: 13000 nM
Compound 4: middle estimate off by 1.4-fold (0.16 log units), on the low side; the measured number falls inside the stated range.
By their numbers in this assay, from the lowest: compound 2; then compounds 4 and 3 (each within the scatter of the next). At a limit, above all of these: compound 1.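

In this assay, chloro in place of hydrogen on an aromatic carbon, para to a large group, is the only single-atom change shown, and it leaves compound 3 and compound 4 within the scatter of each other: a 1.3-fold lower number from compound 3 to compound 4 (0.12 log units; within the scatter). With the 4-chlorophenyl group held constant, the group on the sulfonamide nitrogen now has a readable step of its own, which lies beyond the scatter: a 3.2-fold higher number from compound 2 to compound 4 (0.50 log units; beyond the scatter). The step of an at least 120-fold lower number from compound 1 to compound 4 (2.09 log units; beyond the scatter) starts from a limit of the assay and gives only a bound: the limit of > 1600000 nM in this assay, at which 1 of the 4 values shown sits.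

The compounds shown leave open whether a methoxy group or an amine in place of the chloro would separate from compound 3 in this assay. They also leave open whether a single methyl on the sulfonamide nitrogen would give a step like that of the larger group.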